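The source may report more compounds than this note shows. Statements on the series, on what has been measured and on what is new or still open speak of the compounds shown alone.

Measured compounds:
compound 1, `CNc1nc(NCCCN(C)C)c2sc(-c3ccc(C(F)(F)F)cc3)cc2n1`: 177 ug/mL
compound 2, `CNc1nc(OCCCN(C)C)c2sc(-c3ccc(C(F)(F)F)cc3)cc2n1`: 174 ug/mL
compound 3, `CNc1nc(NC(C)(C)C)c2sc(-c3ccc(C(F)(F)F)cc3)cc2n1`: < 1.6 ug/mL

Among the compounds with values here, compound 3 is the one without a number. In a physicochemical assay for solubility, in phosphate buffer, at pH 6.5 (a lower number here means a less soluble compound, a higher number a more soluble compound), compound 3 gives < 1.6 ug/mL, which is a limit of the assay and not a measured value; this is the limit of < 1.6 ug/mL in this assay, at which 1 of the 3 values shown sits. Compound 1 and compound 2 sit close together, as a 1.0-fold lower number from compound 1 to compound 2 (0.01 log units; within the scatter) shows. Against them compound 3 falls away sharply: an at least 110-fold lower number from compound 1 to compound 3 (2.04 log units; beyond the scatter) and an at least 100-fold lower number from compound 2 to compound 3 (2.03 log units; beyond the scatter), both large, both carrying the tert-butyl group onto the nitrogen on the aromatic ring.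

Compound 4, `CNc1nc(NC2CC2)c2sc(-c3ccc(C(F)(F)F)cc3)cc2n1`, is the next compound to be measured in this assay. It differs from compound 3 by cyclopropyl in place of tert-butyl on a nitrogen on an aromatic ring. Neither measured step covers a cyclopropyl group; the two large steps only show what happens when the 3-(dimethylamino)propyl chain or the 3-(dimethylamino)propoxy group gives way to tert-butyl. The change from tert-butyl to cyclopropyl is a smaller one and keeps the substituent on the same nitrogen. As far as these compounds go, since compound 3 itself stands at a limit, the true size of any step from it is open. The expectation for compound 4 is 5 ug/mL, between 1.5 ug/mL and 30 ug/mL, so that the step of an at least 3.1-fold higher number from compound 3 to compound 4 (0.49 log units; beyond the scatter) is expected to be modest and upward, with a fair chance that compound 4 again reports only a limit.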

Compound 4, solubility: < 5 ug/mL
Compound 4: no number, only a limit; the forecaster's own chance of this, stated with the estimate: 35%; the middle value lies on the limit itself.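

In this assay compound 4 gives < 5 ug/mL, which is a limit of the assay and not a number: the limit of < 5 ug/mL in this assay, at which 1 of the 4 values shown sits. Replacing tert-butyl with cyclopropyl on this nitrogen therefore leaves the compound without a measured value, and the result stands well apart from both compounds that carry a dimethylamino group, with an at least 35-fold lower number from compound 1 to compound 4 (1.54 log units; beyond the scatter) and an at least 34-fold lower number from compound 2 to compound 4 (1.54 log units; beyond the scatter), both large. Among the four compounds shown, the two with a dimethylamino group give measured values and the two with a small carbon substituent give only limits, with no compound going against this, although the step between compound 3 and compound 4 cannot be read.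

The compounds shown leave open how tert-butyl and cyclopropyl truly compare in this assay, and whether any small carbon substituent on this nitrogen would give a measured value at all. They also leave open whether the terminal dimethylamino group or the chain that carries it accounts for the gap, which a chain of the same kind ending in a methoxy group, or a morpholine in place of the dimethylamino group, would begin to separate.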